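The source may hold more compounds than are shown below. What is called first, only, known or untested is meant among the compounds shown, and "the series" means these compounds.

Working notes on the series, as read in a physicochemical assay for solubility, read by spectrophotometry; on this read-out higher numbers stand for higher solubility and lower numbers for lower solubility. Compound 1 `O=C(Nc1ccc(C(F)(F)F)cc1)c1cc(Br)ccc1O` gives < 100000 nM, which is a limit and not a number. Compound 2 `O=C(Oc1ccc(Br)cc1C(=O)Nc1ccc(C(F)(F)F)cc1)c1cnc(Cl)cn1` gives < 100000 nM, which is also a limit. Compound 3 `O=C(NCCCCl)Oc1ccc(Cl)cc1C(=O)Nc1ccc(C(F)(F)F)cc1` gives < 50000 nM, again a limit, so its standing is known only as a limit. No reading so far is a number, and all of them sit at two limits: the limit of < 100000 nM in this assay, at which 2 of the 3 values shown sit, and (the limit of < 50000 nM in this assay, at which 1 of the 3 values shown sits).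

Compound 4 `O=C(NCCCCl)Oc1ccc(Br)cc1C(=O)Nc1ccc(C(F)(F)F)cc1` differs from compound 3 in one place, bromo in place of chloro on an aromatic carbon, para to a ((3-chloropropyl)carbamoyl)oxy group.

Among the compounds with values here, the only measured step is a step that the two limits leave unreadable from compound 1 to compound 2. It concerns the group on the oxygen, not the halogen, and gives no size to carry over. Within the data shown here, compounds 1 and 2 carry bromo, as compound 4 will, but no measured pair shows this swap alone. No step beyond the scatter is therefore expected in this assay, in either direction, and another limit is the likeliest report. The estimated step that the limit leaves unreadable from compound 3 to compound 4 is expected to stay within the scatter. Compound 4 is expected at 30000 nM, with an estimated range of 8000 nM to 60000 nM.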

Compound 4, solubility: < 50000 nM
Compound 4 gave a limit, no number; the forecaster's own chance of this, stated with the estimate: 80%; the middle value lies beyond the limit too.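

In this assay compound 4 gives < 50000 nM, a limit and not a number. No step to compound 4 from compound 1, compound 2 or compound 3 can be read, because compound 4 gives only a limit: the limit of < 50000 nM in this assay, at which 2 of the 4 values shown sit.

The compounds shown leave open whether bromo in place of chloro on the aromatic carbon changes this read-out at all.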